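The compounds below may be only part of what the source reports. "The series", "measured", "known", "first", "only" and "open" are said of these compounds alone.

Compound 2, `Cc1cc(Nc2cc(-c3ccccc3)[nH]n2)n2nc(SCc3ccc(C(F)(F)F)cc3)nc2n1`, is the starting point of this account. In an ADME assay on GES1 cells (Homo sapiens) for inhibition, read by MTT assay, with a stated time of 72 h (a lower number here means a stronger inhibitor, a higher number a weaker inhibitor), compound 2 gives 42700 nM, the second highest of the three numbers measured. Its nearest neighbour is compound 1, `Cc1cc(Nc2cc(-c3ccccc3)[nH]n2)n2nc(SCc3ccc([N+](=O)[O-])cc3)nc2n1`, which in this assay gives 43600 nM; the two differ by a 1.0-fold lower number from compound 1 to compound 2 (0.01 log units; within the scatter), a step that stays within the scatter. The furthest of the three is compound 3, `Cc1cc(Nc2cc(-c3ccc(F)cc3)[nH]n2)n2nc(SCc3ccc(Br)cc3)nc2n1`, which gives 34200 nM in this assay, again within the scatter of compound 2.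

Compound 4, `Cc1cc(Nc2cc(-c3ccccc3)[nH]n2)n2nc(SCC(=O)c3ccccc3)nc2n1`, has not yet been measured. It differs from compound 2 in one place: benzoyl in place of 4-(trifluoromethyl)phenyl on a saturated chain carbon bound to a sulfur. Within the data shown here, the only measured step available changes a group on the aromatic ring of the benzyl part and leaves the number essentially unchanged; no measured step replaces the whole aryl part on the saturated chain carbon bound to a sulfur with a benzoyl group, so the change in compound 4 has no direct precedent among the three compounds. Among the measured compounds shown here, since the one step that does exist, a 1.0-fold lower number from compound 1 to compound 2 (0.01 log units; within the scatter), was within the scatter, no movement beyond the scatter is expected for compound 4 either.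

Compound 4 is therefore estimated at 40000 nM in this assay, with a range from 15000 nM to 110000 nM. The step this estimate implies, a 1.1-fold lower number from compound 2 to compound 4 (0.03 log units; within the scatter), is expected to lie within the scatter.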

Compound 4, half-maximal inhibitory concentration: 33300 nM
Beside the measured number, compound 4's estimate is 1.2-fold (0.08 log units) above it, within the range that was stated.
By their numbers in this assay, from the lowest: compounds 4, 3, 2 and 1 (each within the scatter of the next).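

In this assay, putting benzoyl in place of 4-(trifluoromethyl)phenyl on a saturated chain carbon bound to a sulfur gives a 1.3-fold lower number from compound 2 to compound 4 (0.11 log units; within the scatter), and putting it in place of 4-nitrophenyl at the same place gives a 1.3-fold lower number from compound 1 to compound 4 (0.12 log units; within the scatter). The earlier step, a 1.0-fold lower number from compound 1 to compound 2 (0.01 log units; within the scatter), exchanged only a group on the aromatic ring, whereas these two steps replace the whole aryl part and bring in a carbonyl, so this position keeps the number within the scatter even when 4-(trifluoromethyl)benzyl gives way to benzoylmethyl, a group that carries a hydrogen-bond acceptor. No supporting information is available to account for this outcome.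

From the compounds shown here alone, all the groups compared at this position still carry a six-membered aromatic ring of carbon only, so it remains open whether a group without that ring, such as an amine or a carboxylic acid on the saturated chain carbon, would move the number beyond the scatter. Going by these compounds, it also remains open whether a longer chain between the sulfur and the aromatic ring would leave the number where these compounds place it.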